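Removing a Methoxy Group From a Thiazolyl Phenyl Ring

The compounds below may be only part of what the source reports. "The series", "measured", "known", "first", "only" and "open" are said of these compounds alone.

Measured compounds:
Compound 1, `COc1ccc(-c2nc(SCC(=O)c3sc(-c4ccccc4)nc3C)[nH]c(=O)c2C#N)cc1`: 1.08%
Compound 2, `COc1ccc(-c2nc(C)c(C(=O)CSc3nc(-c4cccc(OC)c4)c(C#N)c(=O)[nH]3)s2)cc1`: 12.4%

Of the compounds shown here, two have been tested in a functional assay on U-87MG ATCC cells for antiproliferative activity against U-87 MG (Homo sapiens), read by MTT assay, with a stated time of 48 h, tested at 100 uM; a lower number here means a stronger effect, a higher number a weaker effect of the compound at the concentration tested. Compound 1 gives 1.08%. Compound 2 gives 12.4% in this assay, which is the higher of the two numbers; the gap to compound 1 lies beyond the scatter, so compound 2 shows the weaker effect of the pair. Going by the values given here, no two measured compounds differ in a single place, so no measured step is available.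

Compound 3, `COc1cccc(-c2nc(SCC(=O)c3sc(-c4ccccc4)nc3C)[nH]c(=O)c2C#N)c1`, is the next compound to be measured. It is derived from compound 2 by a single change: hydrogen in place of methoxy on an aromatic carbon, that is, 4-methoxyphenyl becomes phenyl on the thiazole side. The pyrimidinone side of compound 3 keeps the 3-methoxyphenyl of compound 2, while its thiazole side matches compound 1. Because compound 1 gives 1.08% with the same phenyl on the thiazole, compound 3 is expected to give a lower number than compound 2, with an estimated step of a number 7.4 percentage points lower from compound 2 to compound 3 (within the scatter). The estimate for compound 3 in this assay is 5%, expected to fall between 0% and 25%.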

Compound 3, a percentage reported as activity, at one concentration (the size of the read-out at that concentration, not a potency): 21.8%
Compound 3: middle estimate off by 16.8 percentage points, on the low side, and the stated range covers the measured number.
By their numbers in this assay, from the lowest: compound 1; then compounds 2 and 3 (each within the scatter of the next).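

In this assay, taking the methoxy group off the thiazole-side phenyl ring gives a number 9.4 percentage points higher from compound 2 to compound 3 (within the scatter), so this change has no clear effect on the read-out in this pair, at least while the other phenyl ring carries its 3-methoxyphenyl form. The step that does stand out lies at that other ring: with 3-methoxyphenyl in place of 4-methoxyphenyl and an unsubstituted phenyl on the thiazole side, the measurement gives a number 20.7 percentage points higher from compound 1 to compound 3 (beyond the scatter), which means a weaker effect at the concentration tested. So moving a methoxy group around that ring can change the result clearly, while removing the one on the thiazole-side phenyl did not in this pair, and no measurement at hand explains either result.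

The compounds shown leave open whether removing the thiazole-side methoxy group would also make no clear difference when the other ring carries a 4-methoxyphenyl. They also leave open how an amine, a carboxylic acid or a longer ethoxy chain would behave in place of that methoxy group.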